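Benzyl for Methoxyphenyl: an Unmeasured Neighbour of Compound 3

The compounds below may be only part of what the source reports. "The series", "measured", "known", "first", "only" and "open" are said of these compounds alone.

Compound 1 `CC(C)n1ncc2c(C(=O)NCc3cn(-c4ccccc4)nn3)cccc21`; in a functional assay on MCF7 cells (Homo sapiens) for inhibition, read by MTT assay, with a stated time of 72 h (on this read-out lower numbers stand for stronger inhibition and higher numbers for weaker inhibition), compound 1 gives only the limit > 40000 nM.
Compound 2 `CC(C)n1ncc2c(C(=O)NCc3cn(-c4ccc(C(F)(F)F)cc4)nn3)cccc21`; in this assay compound 2 gives only the limit > 40000 nM.
Compound 3 `COc1ccc(-n2cc(CNC(=O)c3cccc4c3cnn4C(C)C)nn2)cc1`; in this assay compound 3 gives only the limit > 40000 nM.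

Compound 3 thus stands at the assay's limit with no number of its own, and the two other values shown are limits as well. The steps among the measured compounds, a step that the two limits leave unreadable from compound 1 to compound 2, a step that the two limits leave unreadable from compound 1 to compound 3 and a step that the two limits leave unreadable from compound 2 to compound 3, cannot be sized because of the limit of > 40000 nM in this assay, at which 3 of the 3 values shown sit. Compound 4 `CC(C)n1ncc2c(C(=O)NCc3cn(Cc4ccccc4)nn3)cccc21` differs from compound 3 by benzyl in place of 4-methoxyphenyl on an aromatic nitrogen. Among the compounds with values here, no measured step mirrors this change; all that bears on it is that each group tried on that ring nitrogen gave a limit. Compound 4 is therefore expected to show a number no higher from compound 3 to compound 4 (the limit leaves the size open), most probably again as a limit. The value of compound 4 in this assay is estimated at 40000 nM, within 15000 nM to 100000 nM.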

Compound 4, half-maximal inhibitory concentration: 9170 nM
Beside the measured number, compound 4's estimate is 4.4-fold (0.64 log units) above it, and the stated range ends above it.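

On the ring nitrogen, benzyl is the only one of the groups shown that gives a number rather than a limit in this assay. The change gives an at least 4.3-fold lower number from compound 3 to compound 4 (0.63 log units; beyond the scatter), and likewise an at least 4.3-fold lower number from compound 2 to compound 4 (0.63 log units; beyond the scatter) and an at least 4.3-fold lower number from compound 1 to compound 4 (0.63 log units; beyond the scatter). Each step is only a minimum, its true size hidden because of a limit: the limit of > 40000 nM in this assay, at which 3 of the 4 values shown sit.

Going by these compounds, whether a longer chain such as phenethyl on that nitrogen would lower the number further remains open. So does the effect of methoxy or trifluoromethyl on the benzyl ring.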